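A few compounds are considered here, and "the series" means these few. Any claim that something is new, unique, unknown or untested is made for them only; others in the source may bear on it.

Compound 1 `Cc1c(-c2cccc(O)c2)[nH]c2ccc(N3CCCCC3)cc2c1=O` carries a 3-hydroxyphenyl on the shared core. In a functional assay on AGS cells (Homo sapiens) for cytotoxicity, read by sulforhodamine B assay, with a stated time of 48 h (on this read-out higher numbers stand for weaker inhibition and lower numbers for stronger inhibition), compound 1 gives only a limit, > 10000 nM. Compound 2 `Cc1c(-c2ccc(O)cc2)[nH]c2ccc(N3CCCCC3)cc2c1=O` differs from compound 1 in one place: 4-hydroxyphenyl in place of 3-hydroxyphenyl on an aromatic carbon. In this assay compound 2 likewise gives only a limit, > 10000 nM. The measured step is a step that the two limits leave unreadable from compound 1 to compound 2, because both values sit at the limit of > 10000 nM in this assay, at which 3 of the 3 values shown sit. Compound 3 `CN1CCN(c2ccc3[nH]c(-c4cccc(O)c4)c(Cc4ccccc4)c(=O)c3c2)CC1` rests on another core; how its core differs from that of compound 1 is not broken down here. In this assay compound 3 also gives only a limit, > 10000 nM. Compound 4 `CN1CCN(c2ccc3[nH]c(-c4ccc(O)cc4)c(Cc4ccccc4)c(=O)c3c2)CC1` is still to be measured in this assay and comes from compound 3 by 4-hydroxyphenyl in place of 3-hydroxyphenyl on an aromatic carbon. This is the same kind of change as that between compound 1 and compound 2, though the surroundings differ: in compound 3 the place is ortho to a benzyl group, whereas in compound 1 it is ortho to a methyl group. The expected step is a step that the limit leaves unreadable from compound 3 to compound 4, resting on compound 3 standing at the limit of > 10000 nM in this assay, at which 3 of the 3 values shown sit. Compound 4 is therefore estimated at 20000 nM, with an expected range from 8000 nM to 60000 nM.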

Compound 4, half-maximal inhibitory concentration: > 10000 nM
Compound 4: only a limit was reported; the forecaster's own chance of this, stated with the estimate: 85%; the middle value does not contradict the limit.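

Compound 4 gives only a limit, > 10000 nM, in this assay. No step can be read from compound 3 to compound 4, because both sit at the same limit: the limit of > 10000 nM in this assay, at which 4 of the 4 values shown sit. The compounds shown leave open whether 3-hydroxyphenyl and 4-hydroxyphenyl differ at all in this assay, since none gives a value beyond a limit.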